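Swapping the Sulfonyl Substituent in a Macrocyclic Series

The source may hold more compounds than are shown below. What is called first, only, known or untested is meant among the compounds shown, and "the series" means these compounds.

Compound 1 `COc1ccc2c(OCC[C@@H]3NC(=O)N(C)CCCC/C=C\[C@@H]4C[C@@]4(C(=O)NS(=O)(=O)C4(C#N)CC4)NC3=O)cc(-c3nc(C(C)C)cs3)nc2c1Cl` is one of three macrocycles tested in an ADME assay on cells (Homo sapiens) for activation; a lower number here means that less compound is tolerated, a higher number that more compound is tolerated. Compound 1 reaches only a limit there, > 75000 nM, so no exact number is known for it. Compound 2 `COc1ccc2c(OCC[C@@H]3NC(=O)N(C)CCCC/C=C\[C@@H]4C[C@@]4(C(=O)NS(=O)(=O)C4CC4)NC3=O)cc(-c3ccccc3)nc2c1` likewise stops at a limit, > 30000 nM, in this assay. Compound 3 `CCCn1cc(-c2cc(OCC[C@@H]3NC(=O)N(C)CCCC/C=C\[C@@H]4C[C@@]4(C(=O)NS(=O)(=O)C4(C)CC4)NC3=O)c3ccc(OC)c(C)c3n2)cn1` gives a measured value of 62300 nM. Compound 1 therefore stands at the higher of the two limits seen, (the limit of > 75000 nM in this assay, at which 1 of the 3 values shown sits). No two of these compounds differ in a single place, so no measured step exists to guide expectations. Compound 4 `COc1ccc2c(OCC[C@@H]3NC(=O)N(C)CCCC/C=C\[C@@H]4C[C@@]4(C(=O)NS(=O)(=O)N4CCC[C@H]4C#N)NC3=O)cc(-c3nc(C(C)C)cs3)nc2c1Cl` differs from compound 1 by 2-cyanopyrrolidin-1-yl in place of 1-cyanocyclopropyl on a sulfonyl sulfur. The step of an at least 1.0-fold lower number from compound 1 to compound 4 (0.02 log units; that floor lies within the scatter) is expected to stay within the scatter. Compound 4 is expected to give about 70000 nM, between 30000 nM and 100000 nM, quite possibly again only as a limit.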

Compound 4, half-maximal cytotoxic concentration: 28300 nM
Beside the measured number, compound 4's estimate is 2.5-fold (0.39 log units) above it, outside the stated range (below it).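

In this assay, for the compounds shown here, 2-cyanopyrrolidin-1-yl in place of 1-cyanocyclopropyl on a sulfonyl sulfur gives an at least 2.6-fold lower number from compound 1 to compound 4 (0.42 log units; beyond the scatter) and provides the first measured step here, so this position is not indifferent to the change. Compound 1 stands at a limit, so the true step could be larger than this floor. Nothing shown gives a reason for the step.

On these data alone, whether the ring size, the ring nitrogen or the defined stereocentre carries the step stays open. A dimethylamino group on the same sulfonyl sulfur would help separate these.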